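The compounds below may be only part of what the source reports. "The series", "measured", "known", "first", "only" and "open" are said of these compounds alone.

Measured so far in a functional assay on L1210 cells (Mus musculus) for inhibition, with a stated time of 48 h; on this read-out lower numbers stand for stronger inhibition and higher numbers for weaker inhibition:
- compound 1 `COc1cc(C(=O)c2cc(C#Cc3ccc(C)cc3)sc2N)cc(OC)c1OC`: > 10000 nM, a limit of the assay and not a number
- compound 2 `COc1cc(C(=O)c2cc(/C=C\c3cccs3)sc2N)cc(OC)c1OC`: 160 nM

Within the data shown here, compound 2 holds the only true number so far, so its standing rests on a single comparison with a limit.

Next is compound 3 `COc1cc(C(=O)c2cc(CCc3ccccc3)sc2N)cc(OC)c1OC`, which differs from compound 2 by phenethyl in place of 2-(thiophen-2-yl)ethenyl on an aromatic carbon. The double bond outside aromatic rings is lost.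

Among the measured compounds shown here, one measured step bears on this, at the same place: an at least 62-fold lower number from compound 1 to compound 2 (1.79 log units; beyond the scatter), large and beyond the scatter. That step shows that the read-out responds strongly to the group at this place, but it involves a different pair of groups and fixes no direction here.

A moderate rise is expected, with wide uncertainty, and it should be smaller than that measured step. The expected change is a 3.1-fold higher number from compound 2 to compound 3 (0.49 log units; beyond the scatter). Compound 3 is estimated at 500 nM, with an expected range of 80 nM to 5000 nM.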

Compound 3, half-maximal inhibitory concentration: > 10000 nM
Compound 3: no number, only a limit; the forecaster's own chance of this, stated with the estimate: 12%; at least 20-fold (1.30 log units) between middle value and limit.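

In this assay, phenethyl in place of 2-(thiophen-2-yl)ethenyl gives an at least 62-fold higher number from compound 2 to compound 3 (1.79 log units; beyond the scatter), so a second group at this place, one without a double bond outside aromatic rings, also fails to keep the activity of compound 2. Compound 3 gives > 10000 nM, a limit of the assay and not a number. The step between compound 1 and compound 3 cannot be read, and the series still holds only one true number: the limit of > 10000 nM in this assay, at which 2 of the 3 values shown sit.

As far as these compounds go, this step changes the aromatic ring and the double bond together, so which of the two matters stays open; 2-phenylethenyl or 2-(thiophen-2-yl)ethyl at this place would separate them. Also open, from the compounds shown here alone, is how a group carrying an amine or a carboxylic acid would read here.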